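This account rests on a few compounds, and the source may have more. Where it says the series, first, only, none or still open, it means among the compounds named here.

Of the compounds shown here, two from this series have been tested for cytotoxicity. Compound 1 `Cc1cc(S(=O)(=O)/N=C(\N)n2nccc2-c2ccccc2)c(SCc2ccc(C(F)(F)F)cc2)cc1Cl` gives 19000 nM in an ADME assay on HaCaT cells (Homo sapiens) for cytotoxicity, read by MTT assay, with a stated time of 72 h; on this read-out lower numbers stand for stronger inhibition and higher numbers for weaker inhibition. Compound 2 `Cc1cc(-c2ccccc2)n(/C(N)=N/S(=O)(=O)c2cc(C)c(Cl)cc2SCc2cccc(Cl)c2)n1`, which carries a differently substituted benzyl sulfide, gives 18000 nM in this assay, a value within the scatter of that of compound 1, so the two are best read as equal on this read-out. Compound 1 thus stands at the higher end of two numbers that cannot be told apart.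

Compound 3 `Cc1cc(S(=O)(=O)/N=C(\N)n2nccc2-c2ccccc2)c(SCc2ccc(Cl)cc2)cc1Cl` is the next compound to be measured. It differs from compound 1 in one place: chloro in place of trifluoromethyl on an aromatic carbon. Both known compounds share the same core and sulfonyl guanidine, and only the substituent on the benzyl sulfide varies between them without any shift beyond the scatter. Within the data shown here, with no measured step to rest on, compound 3 is expected to show a step of a 1.1-fold lower number from compound 1 to compound 3 (0.02 log units; within the scatter), that is, no change beyond the scatter in either direction. The estimate for compound 3 in this assay is therefore 18000 nM, with a range from 9000 nM to 38000 nM.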

Compound 3, half-maximal inhibitory concentration: 12000 nM
Compound 3: the middle estimate sits 1.5-fold (0.18 log units) above what was measured, within the range that was stated.
By their numbers in this assay, from the lowest: compounds 3, 2 and 1 (each within the scatter of the next).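

In this assay, among these compounds, the exchange of trifluoromethyl for chloro on the benzyl sulfide gives a 1.6-fold lower number from compound 1 to compound 3 (0.20 log units; within the scatter) as the first step that can be read at a single place. At this position, on an aromatic carbon para to a large group, a substituent of four heavy atoms and one of a single heavy atom therefore cannot be told apart on this read-out, and compound 1 and compound 3 are best read as equal. No measurement at hand offers an explanation for this result.

The compounds shown leave open whether a group of another kind at this position, such as an amine, a hydroxyl or a carboxylic acid, would give a step beyond the scatter, and whether plain hydrogen there would read the same as chloro and trifluoromethyl. They also leave open whether the same exchange would stay within the scatter on a compound that differs elsewhere, since this single step rests on one pair of compounds.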